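Prenyl Ether in Place of Succinate Ester on the Chromanol Core

The source may hold more compounds than are shown below. What is called first, only, known or untested is meant among the compounds shown, and "the series" means these compounds.

Measured compounds:
- Compound 1, `C=CCOc1c(C)c(C)c2c(c1C)CCC(C)(COc1ccc(/C=C3\SC(=O)NC3=O)cc1Br)O2`: 98%
- Compound 2, `Cc1c(C)c2c(c(C)c1OC(=O)CCC(=O)O)CCC(C)(COc1ccc(/C=C3\SC(=O)NC3=O)cc1)O2`: 98%

In a functional assay on MCF7 cells (Homo sapiens), tested at 5 uM (on this read-out lower numbers stand for a stronger effect and higher numbers for a weaker effect at the one concentration tested), compound 1 gives 98%. In this assay compound 2 gives 98%. Compound 2 thus stands level with compound 1 at the digits reported, the two values lying within the scatter of each other, so neither can be called the more or less active of the pair.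

Compound 3, `CC(C)=CCOc1c(C)c(C)c2c(c1C)CCC(C)(COc1ccc(/C=C3\SC(=O)NC3=O)cc1)O2`, has not yet been measured. It differs from compound 2 in one place: 3-methylbut-2-en-1-yl in place of (2-carboxyethyl)carbonyl on an oxygen on an aromatic ring. The change removes one hydrogen-bond donor and two acceptors from the side chain and brings in a shorter, all-carbon group.

Compound 1 carries a different ether on the same oxygen and still gives a read-out matching compound 2, so no step beyond the scatter is expected here; the step from compound 2 to compound 3 is estimated at a number 1 percentage points lower from compound 2 to compound 3 (within the scatter). Compound 3 is expected to give 97%, within a range of 85% to 105%.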

Compound 3, a percentage reported as activity, at one concentration (the size of the read-out at that concentration, not a potency): 21%
Estimate against measurement, compound 3: 76 percentage points above; measured number outside the range, below it.
By their numbers in this assay, from the lowest: compound 3; then compounds 1 and 2 (each within the scatter of the next).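

In this assay, putting 3-methylbut-2-en-1-yl in place of (2-carboxyethyl)carbonyl on an oxygen on an aromatic ring gives a number 77 percentage points lower from compound 2 to compound 3 (beyond the scatter), which shows that the read-out responds strongly to what this oxygen carries. Compounds 1 and 2 differ in more than one place, so their level values could not isolate this position, whereas this single-place change does. Nothing available here accounts for the size of the step.

On these data alone, it remains open whether the step follows from the loss of the ester, the loss of the carboxylic acid or the arrival of the 3-methylbut-2-en-1-yl group itself. A simple methyl ether, a longer chain such as geranyl or an amine-bearing chain on the same oxygen would help to tell these apart.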